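Acid to methylamide on the carbonyl of compound 2

The compounds below may be only part of what the source reports. "The series", "measured", "known", "first", "only" and "open" are said of these compounds alone.

In an assay on a protein complex for inhibition of CDK8/Cyclin C (Homo sapiens), with a stated time of 1 h (on this read-out lower numbers stand for stronger inhibition and higher numbers for weaker inhibition), compound 2 `Cn1ccc2cc(-c3cnccc3/C=C/C(=O)O)ccc21` gives 26.8 nM, the lowest of the two numbers available; compound 1 `CCOC(=O)/C=C/c1ccncc1-c1ccc2c(ccn2C)c1` gives 144 nM. Within the data shown here, the only measured step is a 5.4-fold lower number from compound 1 to compound 2 (0.73 log units; beyond the scatter), which went from the ethyl ester to the free acid. Compound 3 `CNC(=O)/C=C/c1ccncc1-c1ccc2c(ccn2C)c1` carries methylamino in place of hydroxy on a carbonyl carbon. Among the measured compounds shown here, no measured step covers this change directly; the ester-to-acid step is the nearest guide, and it favoured the acid over the ester. Compound 3 is therefore expected to give a higher number than compound 2, a step of a 3.0-fold higher number from compound 2 to compound 3 (0.47 log units; beyond the scatter) in this assay. Compound 3 is estimated at 80 nM, with a range from 30 nM to 250 nM.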

Compound 3, half-maximal inhibitory concentration: 77.6 nM
For compound 3 the middle estimate is 1.0-fold (0.01 log units) above the measured one, and the stated range covers the measured number.
By their numbers in this assay, from the lowest: compound 2; then compounds 3 and 1 (each within the scatter of the next).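

On the carbonyl carbon, methylamino in place of hydroxy weakens inhibition in this assay: a 2.9-fold higher number from compound 2 to compound 3 (0.46 log units; beyond the scatter). The free acid therefore stands apart from the methylamide as well as from the ethyl ester, whereas methylamino in place of ethoxy gives no separation: a 1.9-fold lower number from compound 1 to compound 3 (0.27 log units; within the scatter). No available evidence explains the preference for the acid.

Open, from the compounds shown here alone, is whether a primary amide, a dimethylamide or a longer chain on the amide nitrogen would stay with compound 3 or approach compound 2. Going by these compounds, a tetrazole in place of the carboxylic acid also remains open.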